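Acylating an amine: expected solubility of compound 4

The source may report more compounds than this note shows. Statements on the series, on what has been measured and on what is new or still open speak of the compounds shown alone.

- Compound 1 `C[C@H]1[C@H](N)CN1c1nc2c(cc1F)c(=O)c(C(=O)O)cn2C1CC1` gives 23 ug/mL
- Compound 2 `C[C@@H]1[C@@H](NC(=O)[C@@H](C)N)CN1c1nc2c(cc1F)c(=O)c(C(=O)O)cn2C1CC1` gives > 500 ug/mL
- Compound 3 `C[C@H](N)C(=O)N[C@@H]1CN(c2cc3c(cc2F)c(=O)c(C(=O)O)cn3-c2ccc(F)cc2F)[C@H]1C` gives > 500 ug/mL

In a physicochemical assay for solubility (on this read-out higher numbers stand for higher solubility and lower numbers for lower solubility), compound 1 holds the only true number of the three, at the low end of what is shown. The reading of compound 2 is a limit of the assay, not a number. The reading of compound 3 is likewise a limit.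

Compound 4 `CC(C)C[C@H](N)C(=O)N[C@@H]1CN(c2nc3c(cc2F)c(=O)c(C(=O)O)cn3C2CC2)[C@H]1C`, not yet measured, differs from compound 1 by (1-amino-3-methylbutyl)carbonyl in place of hydrogen on an amine nitrogen, with (1-amino-3-methylbutyl)carbonyl in place of hydrogen on an amine nitrogen. Compound 2 also bears an acylated amine, and its limit of > 500 ug/mL is the closest guide. Among the compounds with values here, a rise well beyond the scatter in this assay is therefore expected, a 15-fold higher number from compound 1 to compound 4 (1.18 log units; beyond the scatter), though no measured pair isolates this change. For compound 4 the estimated solubility is 350 ug/mL, with an expected range of 80 ug/mL to 800 ug/mL.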

Compound 4, solubility: > 500 ug/mL
Compound 4 gave a limit, no number; the forecaster's own chance of this, stated with the estimate: 40%; middle value at least 1.4-fold (0.15 log units) from the limit.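

Within the data shown here, with (1-amino-3-methylbutyl)carbonyl in place of hydrogen on this amine nitrogen, this assay gives the first step that can be read at one place: an at least 21-fold higher number from compound 1 to compound 4 (1.33 log units; beyond the scatter). The reading of compound 4 is a limit, not a number, so this step gives only a lower bound. How much further the true value lies cannot be told: the limit of > 500 ug/mL in this assay, at which 3 of the 4 values shown sit.

The compounds shown leave open whether the amino group of this acyl chain is needed for a step of this size. As far as these compounds go, whether a plain acetyl group on the same nitrogen would give a similar step also remains open.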